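Working notes on an amide change in a small series

The source may report more compounds than this note shows. Statements on the series, on what has been measured and on what is new or still open speak of the compounds shown alone.

Measured in an assay on isolated protein for inhibition of aldehyde dehydrogenase 1A1 (Homo sapiens), read by spectrophotometry, tested at 10 uM; a higher number here means more inhibition at the concentration tested (going by the name of the read-out), a lower number less inhibition:
compound 1 `Cc1cccc(Cn2c(CN3CCN(C(=O)c4cccs4)CC3)nc3ccccc32)c1` — 60.8%
compound 2 `COc1cccc(Cn2c(CN3CCN(C(=O)C4CC4)CC3)nc3ccccc32)c1` — 44.4%
compound 3 `O=C(C1CC1)N1CCN(Cc2nc3ccccc3n2Cc2ccc(Cl)cc2)CC1` — 56.6%

Compound 1 holds the highest of the three numbers in this assay; its gap to compound 3 lies within the scatter, so no order between those two is claimed, while its gap to compound 2 lies beyond it. Among the compounds with values here, the one measured single-place step, a number 12.2 percentage points higher from compound 2 to compound 3 (beyond the scatter), concerns the group on the saturated chain carbon bound to the aromatic nitrogen and so does not bear on the change to compound 4 `CCCC(=O)N1CCN(Cc2nc3ccccc3n2Cc2cccc(C)c2)CC1`, which is propyl in place of thiophen-2-yl on a carbonyl carbon. Within the data shown here, no measured pair varies the group on the carbonyl carbon. With nothing pointing either way, the step from compound 1 to compound 4 is expected to stay within the scatter, a number 5.8 percentage points lower from compound 1 to compound 4 (within the scatter). Compound 4 is therefore estimated at 55%, with a range of 38% to 72%.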

Compound 4, a percentage reported as inhibition, at one concentration (the size of the read-out at that concentration, not a potency): 79.1%
Compound 4: middle estimate off by 24.1 percentage points, on the low side, outside the stated range (above it).
By their numbers in this assay, from the lowest: compound 2; then compounds 3 and 1 (each within the scatter of the next); then compound 4.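

In this assay, within the data shown here, the group on the carbonyl carbon proves able to move the read-out, a point no earlier pair could test: propyl in place of thiophen-2-yl gives a number 18.3 percentage points higher from compound 1 to compound 4 (beyond the scatter). In this pair, then, the five-membered aromatic ring is not required for inhibition at the concentration tested, and an open chain carries a higher number. Nothing available explains the step.

On these data alone, whether a longer chain, such as butyl, or a chain bearing an amine would extend or reverse the step stays open. Also open, as far as these compounds go, is whether propyl gives a similar step alongside the 4-chlorophenyl group of compound 3.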